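The source may hold more compounds than are shown below. What is called first, only, known or untested is meant among the compounds shown, and "the series" means these compounds.

compound 1 `C/C(=C\CC/C(C)=C/CC[C@@H]1[C@@]2(C)CCC(=O)C(C)(C)[C@H]2CC[C@@]1(C)O)CC/C=C(\C)C(=O)OCc1cn(-c2cccc(O)c2)nn1`: 42800 nM
compound 2 `C/C(=C\CC/C(C)=C/CC[C@@H]1[C@@]2(C)CCC(=O)C(C)(C)[C@H]2CC[C@@]1(C)O)CC/C=C(\C)C(=O)OCc1cn(-c2ccc(C(F)(F)F)cc2)nn1`: > 150000 nM
compound 3 `C/C(=C\CC/C(C)=C/CC[C@@H]1[C@@]2(C)CCC(=O)C(C)(C)[C@H]2CC[C@@]1(C)O)CC/C=C(\C)C(=O)OCc1cn(-c2ccc(F)cc2)nn1`: > 150000 nM

In a functional assay on A549 cells (Homo sapiens) for antiproliferative activity, read by MTT assay, with a stated time of 48 h (a lower number here means a stronger inhibitor, a higher number a weaker inhibitor), compound 1 gives 42800 nM. For compound 2 the value > 150000 nM is a limit of the assay, not a number. Compound 3 also stands only at a limit, > 150000 nM. Two of the three values shown sit at the limit of > 150000 nM in this assay, at which 2 of the 3 values shown sit. Compound 4 `C/C(=C\CC/C(C)=C/CC[C@@H]1[C@@]2(C)CCC(=O)C(C)(C)[C@H]2CC[C@@]1(C)O)CC/C=C(\C)C(=O)OCc1cn(-c2cccc(F)c2)nn1` differs from compound 3 by 3-fluorophenyl in place of 4-fluorophenyl on an aromatic nitrogen. Among the measured compounds shown here, no measured step merely shifts the fluoro group; the steps touching this phenyl are an at least 3.5-fold higher number from compound 1 to compound 3 (0.54 log units; beyond the scatter) and a step that the two limits leave unreadable from compound 2 to compound 3, the latter unreadable between two limits. Compound 4 is therefore expected to stay near the limit, most likely again reported only as a limit. The expected step is an at least 1.0-fold lower number from compound 3 to compound 4 (0.02 log units; that floor lies within the scatter). The estimate for compound 4 is 140000 nM, ranging from 60000 nM to 300000 nM.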

Compound 4, half-maximal inhibitory concentration: 124000 nM
For compound 4 the middle estimate is 1.1-fold (0.05 log units) above the measured one; measured number inside the range.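

With the fluoro group on the 3-fluorophenyl ring, the comparison with the hydroxy group of compound 1 at the same place becomes readable as a number: a 2.9-fold higher number from compound 1 to compound 4 (0.46 log units; beyond the scatter). Against the other two aryl groups only floors can be read, an at least 1.2-fold lower number from compound 3 to compound 4 (0.08 log units; that floor lies within the scatter) and an at least 1.2-fold lower number from compound 2 to compound 4 (0.08 log units; that floor lies within the scatter), so moving the fluoro group from 4-fluorophenyl to 3-fluorophenyl shows no change beyond the scatter. Both floors rest on one assay limit: the limit of > 150000 nM in this assay, at which 2 of the 4 values shown sit. The compounds shown leave open how an amine or a methoxy group would compare with the hydroxy group of compound 1. They also leave open how a hydroxy group would fare in the place the fluoro group holds in compound 3.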